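Cinnamoyl amide to difluorobenzyl amine on a piperazine nitrogen

The source may report more compounds than this note shows. Statements on the series, on what has been measured and on what is new or still open speak of the compounds shown alone.

Measured in a functional assay on A549 cells (Homo sapiens) for cytotoxicity, read by MTT assay, with a stated time of 48 h; a higher number here means a weaker inhibitor, a lower number a stronger inhibitor:
Compound 1 `CCN(CC)c1ccc2cc(C(=O)c3ccc(N4CCN(C(=O)CN5CCN(C(=O)CCl)CC5)CC4)cc3)oc2c1` gives 3060 nM.
Compound 2 `CCN(CC)c1ccc2cc(C(=O)c3ccc(N4CCN(C(=O)CN5CCN(C(=O)/C=C/c6ccccc6)CC5)CC4)cc3)oc2c1` gives 9450 nM.
Compound 3 `CCN(CC)c1ccc2cc(C(=O)c3ccc(N4CCN(C(=O)CN5CCN(S(=O)(=O)C6CC6)CC5)CC4)cc3)oc2c1` gives 17300 nM.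

Compound 2 sits second highest of the three; nearest is compound 3, a 1.8-fold higher number from compound 2 to compound 3 (0.26 log units; within the scatter), furthest is compound 1, a 3.1-fold higher number from compound 1 to compound 2 (0.49 log units; beyond the scatter). Compound 4 `CCN(CC)c1ccc2cc(C(=O)c3ccc(N4CCN(C(=O)CN5CCN(Cc6ccc(F)c(F)c6)CC5)CC4)cc3)oc2c1` differs from compound 2 in one place: 3,4-difluorobenzyl in place of (2-phenylethenyl)carbonyl on an amine nitrogen in a ring. Among the measured compounds shown here, the steps that bear on this change the group on the same ring nitrogen: a 5.7-fold higher number from compound 1 to compound 3 (0.75 log units; beyond the scatter) and a 3.1-fold higher number from compound 1 to compound 2 (0.49 log units; beyond the scatter), both modest. For the measured compounds named here, no measured compound carries a benzyl group there, so the direction is uncertain. The number for compound 4 in this assay is therefore expected to remain near compound 2, an estimated 1.2-fold lower number from compound 2 to compound 4 (0.07 log units; within the scatter). Compound 4 is estimated at 8000 nM, within 2500 nM to 25000 nM.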

Compound 4, half-maximal inhibitory concentration: 5440 nM
Compound 4: middle estimate off by 1.5-fold (0.17 log units), on the high side, within the range that was stated.
By their numbers in this assay, from the lowest: compounds 1, 4, 2 and 3 (each within the scatter of the next, the first and the last beyond it).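

In this assay the ring nitrogen accepts a benzyl group with no carbonyl attached: a 1.7-fold lower number from compound 2 to compound 4 (0.24 log units; within the scatter) and a 1.8-fold higher number from compound 1 to compound 4 (0.25 log units; within the scatter) both leave the number within the scatter. Against the sulfonyl group the change does register, with a 3.2-fold lower number from compound 3 to compound 4 (0.50 log units; beyond the scatter) and so a gap that the carbonyl-free compound 4 opens beyond the scatter. No measurement here offers a reason for these results. Still open, on these data alone, is what a plain benzyl without fluorine would give on this nitrogen, which would show whether the two fluorines matter. A simple acetyl group would likewise test the chlorine of compound 1.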